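Aryloxyacetamide thiazolidinediones: amide substituent swap in growth inhibition

The source may hold more compounds than are shown below. What is called first, only, known or untested is meant among the compounds shown, and "the series" means these compounds.

Three compounds share one core: compound 1 `Cc1c(NC(=O)COc2ccc(/C=C3\SC(=O)NC3=O)cc2)c(=O)n(-c2ccccc2)n1C`, compound 2 `CCCCC1=NC2(CCCC2)C(=O)N1C(=O)COc1ccc(/C=C2/SC(=O)NC2=O)cc1` and compound 3 `O=C(COc1ccc(/C=C2\SC(=O)NC2=O)cc1)Nc1nc2ccccc2s1`. In a functional assay on KB cells (Homo sapiens) for cytotoxicity, read by sulforhodamine B assay, with a stated time of 48 h (a higher number here means a weaker inhibitor of growth, a lower number a stronger inhibitor of growth), compound 1 gives < 100000 nM, which is a limit of the assay and not a number. Compound 2 gives < 100000 nM in this assay, again only a limit. Compound 3 stands at < 100000 nM in this assay, also a limit rather than a number. Among the measured compounds shown here, no step between measured compounds can be read, since (the limit of < 100000 nM in this assay, at which 3 of the 3 values shown sit). Compound 4 `O=C(COc1ccc(/C=C2\SC(=O)NC2=O)cc1)Nc1ccccn1` carries pyridin-2-yl in place of 1,3-benzothiazol-2-yl on an amide-type nitrogen. For the measured compounds named here, with no measured step to lean on, the change from compound 3 to compound 4 is expected to be a step that the limit leaves unreadable from compound 3 to compound 4, nothing beyond the scatter. For compound 4 the estimate in this assay is 30000 nM, with a range from 3000 nM to 100000 nM.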

Compound 4, concentration for total growth inhibition: < 100000 nM
Compound 4 gave a limit, no number; the forecaster's own chance of this, stated with the estimate: 60%; the middle value lies beyond the limit too.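

No step can be read between compound 3 and compound 4, as neither gives a number, only a limit: the limit of < 100000 nM in this assay, at which 4 of the 4 values shown sit. The compounds shown leave open how strongly each inhibits growth and whether the amide substituent swap matters.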